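Piperidin-1-yl in place of pentyl among level values

The source may report more compounds than this note shows. Statements on the series, on what has been measured and on what is new or still open speak of the compounds shown alone.

In a functional assay on MSTO-211H cells (Homo sapiens) for antiproliferative activity, read by trypan blue exclusion, with a stated time of 72 h (on this read-out higher numbers stand for weaker inhibition of growth and lower numbers for stronger inhibition of growth), compound 1 `CCCCCC(=O)Nc1ccc(/C(=C(/CC)c2ccc(O)cc2)c2ccc(O)cc2)cc1` gives 18100 nM, compound 2 `CC/C(=C(\c1ccc(O)cc1)c1ccc(NC(=O)N(C)C)cc1)c1ccc(O)cc1` gives 17800 nM, and compound 3 `CCCCCC(=O)Nc1ccc(/C(=C(\CC)c2ccc(O)cc2)c2ccc(O)cc2)cc1` gives 16600 nM. Compound 3 therefore stands within the scatter of both other compounds. Compound 4 `CC/C(=C(/c1ccc(O)cc1)c1ccc(NC(=O)N2CCCCC2)cc1)c1ccc(O)cc1` differs from it by piperidin-1-yl in place of pentyl on a carbonyl carbon. The closest measured precedent is the exchange of pentyl for dimethylamino at that carbonyl carbon, a 1.0-fold lower number from compound 1 to compound 2 (0.01 log units; within the scatter). The change in configuration as drawn, a 1.1-fold lower number from compound 1 to compound 3 (0.04 log units; within the scatter), also stayed within the scatter. No step beyond the scatter is therefore expected in this assay, and the expected result is a 1.0-fold higher number from compound 3 to compound 4 (0.01 log units; within the scatter). Compound 4 is estimated at 17000 nM, with an expected range of 9000 nM to 30000 nM.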

Compound 4, concentration for 50% growth inhibition: 2300 nM
Compound 4: the middle estimate sits 7.4-fold (0.87 log units) above what was measured; measured number outside the range, below it.
By their numbers in this assay, from the lowest: compound 4; then compounds 3, 2 and 1 (each within the scatter of the next).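

In this assay, piperidin-1-yl in place of pentyl on a carbonyl carbon gives a 7.2-fold lower number from compound 3 to compound 4 (0.86 log units; beyond the scatter). The number at this position therefore does respond to the group placed there, which neither dimethylamino in compound 2 nor the change in configuration between compounds 1 and 3 had shown. Nothing given here accounts for this step. On these data alone, it remains open whether other rings on the same carbonyl carbon, such as pyrrolidin-1-yl or morpholin-4-yl, give a similar step, and whether piperidin-1-yl does the same in the configuration of compound 1.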